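The compounds below may be only part of what the source reports. "The series", "measured", "known", "first", "only" and "open" are said of these compounds alone.

Within the data shown here, compound 2 `COc1ccc(-n2cnc3cnc(-c4ccc(F)cc4C)cc32)nc1` sits at the better end of the two values measured so far. In a functional assay on HL-60 cells (Homo sapiens) for activation, read by flow cytometry, with a stated time of 4 days (on this read-out higher numbers stand for an effect only at larger amounts of compound and lower numbers for an effect already at smaller amounts), compound 2 gives 30 nM, while compound 1 `Cc1ccc(-n2cnc3cnc(-c4ccc(F)cc4C)cc32)cc1` gives 140 nM in this assay. Among the measured compounds shown here, the only step between measured compounds is a 4.7-fold lower number from compound 1 to compound 2 (0.67 log units; beyond the scatter), which shows that the group on the ring nitrogen matters to this read-out.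

Compound 3 `Cc1cc(F)ccc1-c1cc2c(cn1)ncn2CC1CC1` differs from compound 2 by cyclopropylmethyl in place of 5-methoxypyridin-2-yl on an aromatic nitrogen. For the measured compounds named here, no measured step covers a change of this kind, in which an aromatic group on the ring nitrogen gives way to a small saturated one, so the single step from compound 1 to compound 2 can only indicate that the read-out is sensitive at this position. Compound 3 is therefore expected to give a weaker result, with an estimated step of a 5.0-fold higher number from compound 2 to compound 3 (0.70 log units; beyond the scatter) in this assay. The estimate for compound 3 is 150 nM, with a range from 40 nM to 600 nM.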

Compound 3, half-maximal effective concentration: > 30000 nM
Compound 3: no number, only a limit (the forecaster's own chance of this, stated with the estimate: 10%); middle value at least 200-fold (2.30 log units) away from the limit.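

Compound 3 gives no number in this assay, only a limit of the assay: the limit of > 30000 nM in this assay, at which 1 of the 3 values shown sits.

The change to cyclopropylmethyl is large against both compounds with an aromatic group on the ring nitrogen, with an at least 1000-fold higher number from compound 2 to compound 3 (3.00 log units; beyond the scatter) and an at least 210-fold higher number from compound 1 to compound 3 (2.33 log units; beyond the scatter). Among these three compounds, having an aromatic group at this position therefore counts for far more than the choice between 4-methylphenyl and 5-methoxypyridin-2-yl, where the step is a 4.7-fold lower number from compound 1 to compound 2 (0.67 log units; beyond the scatter).

With only one saturated group shown, it stays open whether the aromatic ring itself or the larger size of the group matters, and a benzyl group or a cyclohexyl ring on the ring nitrogen would separate the two. Also open, on these data alone, is how an amine or a carboxylic acid on the aromatic group would read.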